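Methyl to ethyl on the core of compound 1

The compounds below may be only part of what the source reports. "The series", "measured", "known", "first", "only" and "open" are said of these compounds alone.

Among the compounds with values here, compound 1 `CCCN(CCC)c1ccc(C)c2nc(-c3c(OC)cc(COC)cc3OC)c(C)cc12` is the only member of this set with a number in hand. In a functional assay on HEK293 cells for antagonist activity at corticotropin-releasing factor receptor 1 (Homo sapiens), read by cAMP accumulation and immunoassay, with a stated time of 30 min (on this read-out lower numbers stand for stronger inhibition and higher numbers for weaker inhibition), compound 1 gives 70 nM, so it stands alone and cannot be ranked against anything measured. Compound 2 `CCC(CC)Nc1ccc(C)c2nc(-c3c(OC)cc(COC)cc3OC)c(C)cc12` and compound 3 `COCCNc1ccc(C)c2nc(-c3c(OC)cc(COC)cc3OC)c(C)cc12` share the core and carry different amines on it, but for both no result was reported in this assay, so they add nothing to the comparison: in this assay compound 2 gives "not determined" (no result reported), and in this assay compound 3 gives "not determined" (no result reported).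

Compound 4 `CCCN(CCC)c1ccc(CC)c2nc(-c3c(OC)cc(COC)cc3OC)c(C)cc12` keeps the dipropylamino group and the two methoxy groups of compound 1 and differs from it in one place only: methyl in place of hydrogen on a saturated chain carbon bound to an aromatic carbon. Cut one bond further out, this reads as methyl to ethyl. Within the data shown here, no measured pair in this set shows what such a change does to inhibition, so there is no step to lean on. A single extra carbon on a saturated chain bound to the core is the kind of change that, in series like this, usually moves the half-maximal inhibitory concentration little, and the expectation here is a step from compound 1 to compound 4 of a 1.2-fold lower number from compound 1 to compound 4 (0.07 log units; within the scatter), essentially none beyond the scatter. Compound 4 is therefore estimated at 60 nM in this assay, with a plausible range from 25 nM to 170 nM.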

Compound 4, half-maximal inhibitory concentration: 375 nM
The estimate for compound 4 lay 6.3-fold (0.80 log units) below the measured number, outside the stated range (above it).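

In this assay, methyl in place of hydrogen on a saturated chain carbon bound to an aromatic carbon gives a 5.4-fold higher number from compound 1 to compound 4 (0.73 log units; beyond the scatter), so methyl to ethyl at this place on the shared core moves towards weaker inhibition by more than the usual scatter. Within the data shown here, until compound 4, the series held a single number and no step, so this is the first indication that inhibition responds to a change at this position, although it rests on one pair. No data at hand bear on why the number rises.

As far as these compounds go, whether a longer chain such as propyl would continue this direction, or whether a different group such as chlorine or methoxy at this position would behave otherwise, remains open, as one step does not define a trend. From the compounds shown here alone, with no number for compound 2 or compound 3, the effect of the amine on the shared core also cannot be judged, and it is unknown whether methyl to ethyl would have the same effect alongside those amines.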